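Chloro for Methyl on the Aryl Imine

This account rests on a few compounds, and the source may have more. Where it says the series, first, only, none or still open, it means among the compounds named here.

Three compounds sharing one core were measured in a functional assay on HepG2 cells (Homo sapiens) for cytotoxicity, read by sulforhodamine B assay, with a stated time of 24 h; a higher number here means a weaker inhibitor, a lower number a stronger inhibitor. Compound 1 `Cc1ccc(/N=C2\C(=O)Nc3ccc(S(=O)(=O)N4CCOCC4)cc32)cc1` gives 12800 nM, the second highest of the three numbers. Compound 2 `O=C1Nc2ccc(S(=O)(=O)N3CCOCC3)cc2/C1=N/c1ccc(O)cc1` gives 10400 nM, and compound 3 `O=C1Nc2ccc(S(=O)(=O)N3CCOCC3)cc2/C1=N/NS(=O)(=O)c1ccccc1` gives 23900 nM. The step of a 1.2-fold lower number from compound 1 to compound 2 (0.09 log units; within the scatter) lies within the scatter, as does a 1.9-fold higher number from compound 1 to compound 3 (0.27 log units; within the scatter); only a 2.3-fold higher number from compound 2 to compound 3 (0.36 log units; beyond the scatter) reaches beyond it, and modestly. Compound 4 `O=C1Nc2ccc(S(=O)(=O)N3CCOCC3)cc2/C1=N/c1ccc(Cl)cc1` differs from compound 1 by chloro in place of methyl on an aromatic carbon. Going by the values given here, no measured step swaps methyl for chloro; the nearest guide is the exchange of methyl for hydroxy on an aromatic carbon, which moved the number by a 1.2-fold lower number from compound 1 to compound 2 (0.09 log units; within the scatter). Compound 4 is therefore expected to stay within the scatter of compound 1, a step of a 1.1-fold lower number from compound 1 to compound 4 (0.03 log units; within the scatter). The estimate for compound 4 is 12000 nM, with a range from 6000 nM to 25000 nM.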

Compound 4, half-maximal inhibitory concentration: 11800 nM
Estimate against measurement, compound 4: 1.0-fold (0.01 log units) above; low and high end bracket the measured number.
By their numbers in this assay, from the lowest: compounds 2, 4, 1 and 3 (each within the scatter of the next, the first and the last beyond it).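

In this assay, chloro joins methyl and hydroxy on this aromatic carbon without separating from either, whether it replaces methyl (a 1.1-fold lower number from compound 1 to compound 4 (0.04 log units; within the scatter)) or hydroxy (a 1.1-fold higher number from compound 2 to compound 4 (0.05 log units; within the scatter)). Replacing (phenylsulfonyl)amino with 4-chlorophenyl on the double-bonded nitrogen gives a modest step beyond the scatter (a 2.0-fold lower number from compound 3 to compound 4 (0.31 log units; beyond the scatter)), although the corresponding step between compound 1 and compound 3 stays within it. No available evidence explains these results. The compounds shown leave open whether an amine, a carboxylic acid or a longer chain at this aromatic carbon would move the number beyond the scatter.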